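The compounds below may be only part of what the source reports. "The series", "measured", "known", "first", "only" and "open" are said of these compounds alone.

Compound 1 `CC(=O)c1ccc(NC(=O)Cn2nc(-c3ccc(Cl)cc3)nc2N)cc1`: 20.6%
Compound 2 `C/C(=N\O)c1ccc(NC(=O)Cn2nc(-c3ccc(Cl)cc3)nc2N)cc1`: 34%
Compound 3 `CC(=O)c1ccc(NC(=O)Cn2nc(C(F)(F)F)nc2N)cc1`: not yet measured

Among the compounds with values here, in a functional assay on UO-31 cells (Homo sapiens) for inhibition, read by sulforhodamine B assay, with a stated time of 48 h, tested at 10 uM (a lower number here means less inhibition of growth, a higher number more inhibition of growth at the concentration tested), compound 1 gives 20.6%, the lower of the two numbers measured so far. Compound 3 keeps the rest of compound 1 and changes one group: trifluoromethyl in place of 4-chlorophenyl on an aromatic carbon. The swap replaces a ring-bearing group with a smaller one that has no ring, and it sits on an aromatic carbon.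

Within the data shown here, only one measured step is available as a guide: a number 13.4 percentage points higher from compound 1 to compound 2 (beyond the scatter). That step is modest, and it changes a different part of the molecule, leaving the 4-chlorophenyl in place. It therefore shows how far one small edit can move this read-out, but not what losing the 4-chlorophenyl does. Among the measured compounds shown here, no measured compound lacks that group, so the direction stays open. A small step within the scatter is expected, with a slight lean downward. The expected result is a number 3.6 percentage points lower from compound 1 to compound 3 (within the scatter). For compound 3 the estimate is 17%, with an expected range of 2% to 35%.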

Compound 3, percent growth inhibition at one concentration: 13.7%
Estimate against measurement, compound 3: 3.3 percentage points above, and the stated range covers the measured number.
By their numbers in this assay, from the lowest: compounds 3 and 1 (each within the scatter of the next); then compound 2.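

In this assay, the step of a number 6.9 percentage points lower from compound 1 to compound 3 (within the scatter) shows that the aromatic carbon between two ring nitrogen atoms can give up 4-chlorophenyl for trifluoromethyl without a difference this read-out can separate from the usual scatter. A group with one six-membered aromatic ring and a smaller group with no ring therefore cannot be told apart here, so the ring of 4-chlorophenyl is not shown to be needed for the growth inhibition seen with compound 1. Nothing measured on these compounds explains why this swap leaves the two numbers so close.

On these data alone, what other groups at this position would do remains open: a plain phenyl, a methyl, a primary amine or a carboxylic acid could each stay within the scatter or move the number beyond it. Within the data shown here, it is also open whether the edit that separates compound 2 from compound 1 would give a similar step on a compound carrying trifluoromethyl, since the only measured example of that edit keeps 4-chlorophenyl in place.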